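The compounds below may be only part of what the source reports. "The series", "measured", "known", "first", "only" and "open" are said of these compounds alone.

Compound 1, `N#Cc1ccc(-c2cc(-c3ccc(C(N)=O)cc3)cc(-c3cnco3)n2)cc1`, gives 250000 nM.
Compound 2, `c1coc(-c2cc(-c3nccs3)cc(-c3ccc(-c4nccs4)cc3)n2)c1`, gives < 1000 nM, which is a limit of the measurement and not a number.
Compound 3, `N#Cc1ccc(-c2cc(-c3ccc(-c4nnn[nH]4)cc3)cc(-c3ccco3)n2)cc1`, gives 18000 nM.

All three share the same core, a six-membered aromatic ring with one nitrogen carrying three aryl groups, and differ in what those groups are. In a physicochemical assay for solubility, at pH 6 (a higher number here means a more soluble compound, a lower number a less soluble compound), compound 1 holds the highest of the two real numbers. Compound 3 sits well below it, a gap beyond the usual scatter. For compound 2 the result is only a limit: the limit of < 1000 nM in this assay, at which 1 of the 3 values shown sits.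

The compound that has not yet been measured is compound 4, `N#Cc1ccc(-c2cc(-c3ccc(C(N)=O)cc3)cc(-c3cccc(F)c3)n2)cc1`. It keeps the carbamoylphenyl and cyanophenyl groups of compound 1 and changes one ring: 3-fluorophenyl in place of 1,3-oxazol-5-yl on an aromatic carbon. The new group brings no hydrogen-bond acceptors where the old one brought two.

Within the data shown here, no pair of measured compounds differs in exactly this way, so the step is an expectation rather than a measured one. The expected step in this assay is a 6.3-fold lower number from compound 1 to compound 4 (0.80 log units; beyond the scatter), downward and beyond the scatter. For compound 4 the estimated solubility is 40000 nM, with a range from 8000 nM to 150000 nM.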

Compound 4, solubility: 2000 nM
Beside the measured number, compound 4's estimate is 20-fold (1.30 log units) above it; the measured number lies below the stated range.
By their numbers in this assay, from the lowest: compound 4; then compound 3; then compound 1. At a limit, below all of these: compound 2.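

Replacing 1,3-oxazol-5-yl with 3-fluorophenyl, while the 4-carbamoylphenyl and 4-cyanophenyl groups stay in place, gives a 130-fold lower number from compound 1 to compound 4 (2.10 log units; beyond the scatter) in this assay. Among these compounds, this is the first change that can be read on its own, and it shows that this one position, on an aromatic carbon next to the ring nitrogen, can by itself move the read-out by a large amount. Further falls from compound 4 may have little readable range left, as compound 2 stands at a limit of the measurement and not at a number: the limit of < 1000 nM in this assay, at which 1 of the 4 values shown sits.

Among the compounds shown here, the single swap changes several things at once: ring size, the hetero atoms in the ring, the hydrogen-bond acceptor count and the presence of fluorine, and these two compounds cannot tell which of them matters. Also open, on these data alone, is how a ring carrying an amine or a carboxylic acid at this same position would read, and whether the step would keep its size on a core with different groups at the other two positions.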